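The compounds below may be only part of what the source reports. "The series", "measured", "known", "first", "only" and "open" are said of these compounds alone.

Measured compounds in a functional assay on G-361 cells (Homo sapiens) for cytotoxicity, read by sulforhodamine B assay; a higher number here means that more compound is tolerated, a lower number that less compound is tolerated:
compound 1 `Cc1nc(NC(C)C)c2cnn(-c3ccccc3)c2n1`: compound 1 gives > 100000 nM, which is a limit of the assay and not a number
compound 2 `CCCCNc1nc(C)nc2c1cnn2-c1ccccc1`: compound 2 gives > 100000 nM, again a limit of the assay
compound 3 `CCc1nc(NC(C)C)c2cnn(-c3ccccc3)c2n1`: compound 3 gives > 100000 nM, also a limit of the assay

The change from compound 1 to compound 2 is butyl in place of isopropyl on a nitrogen on an aromatic ring; the step it made, a step that the two limits leave unreadable from compound 1 to compound 2, cannot be sized. The cores of compound 1 and compound 3 differ by methyl in place of hydrogen on a saturated chain carbon bound to an aromatic carbon, and that step, a step that the two limits leave unreadable from compound 1 to compound 3, is equally unreadable. Going by the values given here, every value so far sits at the limit of > 100000 nM in this assay, at which 3 of the 3 values shown sit, so no step in this assay has a readable size.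

Compound 4 `CCCCNc1nc(CC)nc2c1cnn2-c1ccccc1` is still to be measured. It differs from compound 3 by butyl in place of isopropyl on a nitrogen on an aromatic ring, the same change as from compound 1 to compound 2, at a place described in the same words. The step that the limit leaves unreadable from compound 3 to compound 4 is expected to be flat because compound 1 and compound 2 both sit at the limit of > 100000 nM in this assay, at which 3 of the 3 values shown sit, so the likeliest outcome is again a limit rather than a number. Compound 4 is estimated at 150000 nM, between 60000 nM and 400000 nM.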

Compound 4, concentration lethal to 50% of the cells: > 100000 nM
Compound 4: a limit, no number (the forecaster's own chance of this, stated with the estimate: 85%); the middle value is on the limit's open side.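

In this assay compound 4 gives > 100000 nM, a limit of the assay and not a number. Neither step to compound 4, from compound 2 or from compound 3, can be read: the limit of > 100000 nM in this assay, at which 4 of the 4 values shown sit.

The compounds shown leave open whether butyl in place of isopropyl, or methyl in place of hydrogen, changes the value at all in this assay.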